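A few compounds are considered here, and "the series" means these few. Any claim that something is new, unique, unknown or untested is made for them only; others in the source may bear on it.

Working notes on the series.

Compound 1 `CCCCc1cn(CCNc2nonc2/C(=N/O)Nc2ccc(F)c(Br)c2)nn1` in an assay on isolated protein for inhibition of Indoleamine 2,3-dioxygenase 2 (Homo sapiens) (a higher number here means a weaker inhibitor, a lower number a stronger inhibitor), gives 830 nM. Within the data shown here, compound 2 `OCCc1cn(CCNc2nonc2/C(=N/O)Nc2ccc(F)c(Br)c2)nn1` in this assay gives 1170 nM, the highest of the two numbers measured so far; its nearest neighbour is compound 1, and the step of a 1.4-fold higher number from compound 1 to compound 2 (0.15 log units; within the scatter) lies within the scatter, so no order between the two can be read.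

Compound 3 `OCCCc1cn(CCNc2nonc2/C(=N/O)Nc2ccc(F)c(Br)c2)nn1` is not yet measured. It differs from compound 2 by hydroxymethyl in place of hydroxy on a saturated chain carbon, two bonds along the chain from an aromatic carbon. Among the measured compounds shown here, the only measured step that bears on this part of the molecule is the one from compound 1 to compound 2, and that step was a 1.4-fold higher number from compound 1 to compound 2 (0.15 log units; within the scatter), within the scatter. On that basis the step of a 1.2-fold lower number from compound 2 to compound 3 (0.07 log units; within the scatter) in this assay is expected to stay within the scatter as well, in no settled direction. For compound 3 a value of 1000 nM is therefore estimated, with a range from 500 nM to 2100 nM.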

Compound 3, half-maximal inhibitory concentration: 958 nM
Compound 3: the middle estimate sits 1.0-fold (0.02 log units) above what was measured; the measured number falls inside the stated range.
By their numbers in this assay, from the lowest: compounds 1, 3 and 2 (each within the scatter of the next).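

In this assay, the change from 2-hydroxyethyl to 3-hydroxypropyl gives a 1.2-fold lower number from compound 2 to compound 3 (0.09 log units; within the scatter), so the hydroxy group can sit one carbon further out on this chain with no readable change. Hydroxy in place of methyl on a saturated chain carbon, three bonds along the chain from an aromatic carbon, gives a 1.2-fold higher number from compound 1 to compound 3 (0.06 log units; within the scatter), so across these three compounds neither the chain length nor the terminal hydroxy separates the values. Nothing is available to account for this flat response.

As far as these compounds go, whether it would hold for an amine or a carboxylic acid at the chain end, or for a longer hydroxyalkyl chain, remains open. Also open is whether any group at this position can move the value beyond the scatter, as all three compounds shown carry an unbranched chain on the same core.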